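Chloro for hydrogen on two benzofuran-bearing indolyl cores

The source may hold more compounds than are shown below. What is called first, only, known or untested is meant among the compounds shown, and "the series" means these compounds.

Compound 1 `CC(C)(C)c1cc(C(C)(C)C)c2oc(C(c3ccccc3)c3c[nH]c4ccc([N+](=O)[O-])cc34)cc2c1` and compound 2 `CC(C)(C)c1cc(C(C)(C)C)c2oc(C(c3ccc(Cl)cc3)c3c[nH]c4ccc([N+](=O)[O-])cc34)cc2c1` share one core; compound 3 `Cc1c(C(c2ccccc2)c2cc3ccccc3o2)[nH]c2ccccc12` and the unmeasured compound 4 `Cc1c(C(c2ccccc2)c2cc3cc(Cl)ccc3o2)[nH]c2ccccc12` share another. The difference between the two cores is not broken down here.

In a functional assay on SiHa cells (Homo sapiens) for cytotoxicity (a higher number here means a weaker inhibitor, a lower number a stronger inhibitor), compound 1 gives 48200 nM and compound 2 gives 36900 nM. The change between them is chloro in place of hydrogen on an aromatic carbon, and it made a step of a 1.3-fold lower number from compound 1 to compound 2 (0.12 log units; within the scatter). For compound 3 the result in this assay is only a limit, > 100000 nM, and that limit is the limit of > 100000 nM in this assay, at which 1 of the 3 values shown sits.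

From compound 3 to compound 4 the change is chloro in place of hydrogen on an aromatic carbon. Among the measured compounds shown here, it is the same kind of change as the one from compound 1 to compound 2, not the same: there the place was para to a large group, here it is part of a fused or bridged system of two rings, meta to a fused ring and para to a fused ring. Since the measured step of a 1.3-fold lower number from compound 1 to compound 2 (0.12 log units; within the scatter) stayed within the scatter, compound 4 is expected to move little from compound 3, by about a step that the limit leaves unreadable from compound 3 to compound 4. Compound 4 is therefore estimated at 140000 nM in this assay, with a range of 60000 nM to 400000 nM, and most likely again only a limit.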

Compound 4, half-maximal inhibitory concentration: 77900 nM
Compound 4: the middle estimate sits 1.8-fold (0.25 log units) above what was measured; the measured number falls inside the stated range.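

In this assay, chloro in place of hydrogen on an aromatic carbon was carried to a second core, giving an at least 1.2-fold lower number from compound 3 to compound 4 (0.10 log units; that floor lies within the scatter). The earlier step lies within the scatter and only a floor is known for the new one, so the notes show neither that the change carries over at the same size nor that its size differs between the cores: the same change on two cores in this assay, a 1.3-fold lower number (0.12 log units; within the scatter) from compound 1 to compound 2 and an at least 1.2-fold lower number (0.10 log units; that floor lies within the scatter) from compound 3 to compound 4; the limit leaves it open whether they differ. As far as these compounds go, compound 3 stands only at a limit, > 100000 nM, and the true size of the new step remains unknown: the limit of > 100000 nM in this assay, at which 1 of the 4 values shown sits.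

Among the compounds shown here, the change appears at only one place on each core, on the ring bearing a large group in the core of compound 1 and on the fused system of two rings in the core of compound 3, so it remains open whether the place or the core governs the step. Also open, from the compounds shown here alone, is how an amine, a carboxylic acid or a methoxy group would read at these same places on either core.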